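Coumarin pyrazoline series: nitrophenyl replacing styryl

The compounds below may be only part of what the source reports. "The series", "measured", "known", "first", "only" and "open" are said of these compounds alone.

Measured compounds:
compound 1 `COc1ccc([C@H]2CC(c3cc4ccccc4oc3=O)=NN2c2ccccc2)cc1` gives 36.2%
compound 2 `O=c1oc2ccccc2cc1C1=NN(c2ccccc2)[C@@H](/C=C/c2ccccc2)C1` gives 42.5%
compound 3 `CN(C)c1ccc([C@H]2CC(c3cc4ccccc4oc3=O)=NN2c2ccccc2)cc1` gives 40.1%

In a functional assay on the whole organism (strain albino) for inhibition, with Rattus norvegicus as the target, read by paw edema, with stated times of 1 h and 4 h, at a dose of 200 mg/kg by the oral route (a higher number here means more inhibition at the dose given (going by the name of the read-out), a lower number less inhibition), compound 2 cannot be separated from its neighbours: the step of a number 6.3 percentage points higher from compound 1 to compound 2 (within the scatter) and the step of a number 2.4 percentage points lower from compound 2 to compound 3 (within the scatter) both lie within the scatter, as does a number 3.9 percentage points higher from compound 1 to compound 3 (within the scatter). On the numbers shown, compound 2 stands level with compounds 1 and 3.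

Compound 4 `O=c1oc2ccccc2cc1C1=NN(c2ccccc2)[C@@H](c2cccc([N+](=O)[O-])c2)C1` differs from compound 2 at the saturated ring carbon: 3-nitrophenyl in place of 2-phenylethenyl on a saturated ring carbon

Going by the values given here, the steps that bear on this place are a number 6.3 percentage points higher from compound 1 to compound 2 (within the scatter) and a number 2.4 percentage points lower from compound 2 to compound 3 (within the scatter), each within the scatter; two different aryl groups and the 2-phenylethenyl group all read alike here. A third aryl group, 3-nitrophenyl, is therefore expected to give no step beyond the scatter in this assay, and the expected step of a number 2.5 percentage points lower from compound 2 to compound 4 (within the scatter) is small. Compound 4 is estimated at 40%, in the range 30% to 50%.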

Compound 4, a percentage reported as inhibition, in the whole organism at one dose (the size of the read-out at that dose, not a potency): 31.2%
Estimate against measurement, compound 4: 8.8 percentage points above; measured number inside the range.
By their numbers in this assay, from the lowest: compounds 4, 1, 3 and 2 (each within the scatter of the next, the first and the last beyond it).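

In this assay, going by these compounds alone, the saturated ring carbon now shows that the group it carries can move the read-out, if only modestly: a number 11.3 percentage points lower from compound 2 to compound 4 (beyond the scatter) is the first step at this position to pass the scatter. The change does not separate 3-nitrophenyl from the other two aryl groups, as a number 8.9 percentage points lower from compound 3 to compound 4 (within the scatter) and a number 5 percentage points lower from compound 1 to compound 4 (within the scatter) both stay within the scatter, so the separation holds against 2-phenylethenyl alone. No measurement at hand accounts for this step.

From the compounds shown here alone, whether an amine or a carboxylic acid on this carbon would read differently stays open. A plain phenyl group at the same place would show whether the step follows the nitro group or the loss of 2-phenylethenyl.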